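The compounds below may be only part of what the source reports. "The series", "measured", "known", "first", "only" and "open" are said of these compounds alone.

Working notes on the series.

Three compounds have numbers in an assay on membranes from CHO cells for displacement of a labelled ligand from adenosine receptor A1 (Homo sapiens), read by scintillation counting, with a stated time of 60 min, tested at 1 uM (on this read-out higher numbers stand for more inhibition at the one concentration tested (going by the name of the read-out) and lower numbers for less inhibition), so far. Compound 1 `CC1=C(C(=O)OC(C)(C)C)C(c2ccsc2)NC(=O)N1` gives 15% in this assay. Compound 2 `CC(=O)C1=C(C)NC(=O)NC1c1ccoc1` gives 6% in this assay. Compound 3 `CC1=C(C(=O)C2CC2)C(c2ccoc2)NC(=O)N1` gives 1% in this assay. Compound 2 sits between the other two numbers, and neither gap separates it from them: the change a number 5 percentage points lower from compound 2 to compound 3 (within the scatter) lies within the scatter, and the gap between compound 2 and compound 1 is also within the scatter, so the three are indistinguishable on this read-out.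

The next compound, compound 4 `CC(=O)C1=C(C)NC(=O)NC1c1ccsc1`, differs from compound 2 in one place: thiophen-3-yl in place of furan-3-yl on a saturated ring carbon

Among the measured compounds shown here, no measured step covers this change alone. For the measured compounds named here, the one measured step, the cyclopropyl in place of methyl on a carbonyl carbon from compound 2 to compound 3, concerns a different part of the molecule and was within the scatter. Compound 1 carries the thiophen-3-yl but also a different ester group, so it differs from compound 2 in two places. In this assay compound 1 gives 15%, and that number nonetheless sits within the scatter of the number of compound 2. Compound 4 is therefore expected to show no step beyond the scatter, an expected change of a number 4 percentage points higher from compound 2 to compound 4 (within the scatter). For compound 4 the estimate in this assay is 10%, with a range from 0% to 25%.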

Compound 4, a percentage reported as inhibition, at one concentration (the size of the read-out at that concentration, not a potency): 9%
Beside the measured number, compound 4's estimate is 1 percentage points above it; low and high end bracket the measured number.
By their numbers in this assay, from the lowest: compounds 3, 2, 4 and 1 (each within the scatter of the next, the first and the last beyond it).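

In this assay the exchange of furan-3-yl for thiophen-3-yl on the saturated ring carbon can now be read on its own, with the acetyl group held fixed: the step is a number 3 percentage points higher from compound 2 to compound 4 (within the scatter) and does not separate the two rings at this position. With thiophen-3-yl held fixed, compound 4 also isolates the group on the carbonyl carbon, which compound 1 and compound 2 could not do because they differ in two places; methyl in place of tert-butoxy gives a number 6 percentage points lower from compound 1 to compound 4 (within the scatter) and does not separate that pair either. No measurement is available that bears on these results.

At this position the compounds shown cover only furan-3-yl and thiophen-3-yl, so it remains open whether a phenyl ring or a longer chain ending in an amine on the saturated ring carbon would give a number beyond the scatter. As far as these compounds go, on the carbonyl side, it also remains open what a carboxylic acid in place of the acetyl group would give.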